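Hydroxy for hydrogen on two related macrocyclic cores

The source may hold more compounds than are shown below. What is called first, only, known or untested is meant among the compounds shown, and "the series" means these compounds.

Compound 1 `Oc1ccc2c(c1)CCc1ccc(O)c(c1)Oc1ccc(cc1)CCc1cccc(O)c1O2` is the reference on the first core. In a functional assay on HeLa cells (Homo sapiens) for antiproliferative activity, read by MTT assay, with a stated time of 48 h (on this read-out higher numbers stand for weaker inhibition and lower numbers for stronger inhibition), compound 1 gives 15900 nM. Compound 2 `Oc1ccc2c(c1)CCc1ccc(O)c(c1)Oc1ccc(cc1O)CCc1cccc(O)c1O2` carries one more hydroxy group; the change is hydroxy in place of hydrogen on an aromatic carbon. In this assay compound 2 gives 26800 nM, and the step is a 1.7-fold higher number from compound 1 to compound 2 (0.23 log units; within the scatter).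

Compound 3 `Oc1ccc2cc1Oc1ccc(cc1)CCc1ccc(O)c(c1)Oc1cccc(c1)CC2` is built on a second core; how the two cores differ is not broken down here. In this assay compound 3 gives 11700 nM. Against compound 1 the gap is within the scatter, so no order between these two is claimed; against compound 2 the gap is beyond the scatter.

Compound 4 `Oc1ccc2cc1Oc1cccc(c1)CCc1ccc(O)c(c1)Oc1ccc(cc1O)CC2` has not yet been measured. It differs from compound 3 by hydroxy in place of hydrogen on an aromatic carbon, and the place is described in the same words as for the change from compound 1 to compound 2, so the two changes are treated as the same change, made on two different cores. On the first core that change gave a 1.7-fold higher number from compound 1 to compound 2 (0.23 log units; within the scatter), a step within the scatter. For the measured compounds named here, with only this one example to go on, the expected step from compound 3 to compound 4 is a 1.6-fold higher number from compound 3 to compound 4 (0.21 log units; within the scatter), resting on the value of compound 3 11700 nM and the size of the earlier step. Compound 4 is therefore estimated at 19000 nM, with a range from 9000 nM to 42000 nM, pending the measurement.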

Compound 4, half-maximal inhibitory concentration: 19500 nM
Estimate against measurement, compound 4: 1.0-fold (0.01 log units) below, and the stated range covers the measured number.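

In this assay, hydroxy in place of hydrogen on an aromatic carbon gives a 1.7-fold higher number from compound 3 to compound 4 (0.22 log units; within the scatter), and beside the matching step on the core of compound 1 the change carries over with no difference that can be told apart: the same change on two cores in this assay, a 1.7-fold higher number (0.23 log units; within the scatter) from compound 1 to compound 2 and a 1.7-fold higher number (0.22 log units; within the scatter) from compound 3 to compound 4, 1.0-fold (0.00 log units) apart, within the scatter of two such steps. This is agreement between two small steps: in both pairs the added hydroxy leaves the number within the scatter, on the core of compound 1 and on the core of compound 3 alike. It does not show that this hydroxy moves antiproliferative activity in either direction, and two pairs in a single assay give no rule for other cores of the series or for other places on the aromatic rings.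

Hydroxy is the only group varied in the pairs shown, so it remains open whether a methoxy, a fluorine, an amine or a carboxylic acid on the same aromatic carbon would give a step beyond the scatter. Also open, going by these compounds, is what replacing the hydroxy groups already present on these cores with hydrogen or methoxy would do to the number.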